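Trading a ring for a chain at the pyridine flank

The source may hold more compounds than are shown below. What is called first, only, known or untested is meant among the compounds shown, and "the series" means these compounds.

Compound 3 `CCC1CC=C(c2nc(C(F)(F)F)ccc2CNC(=O)C(C)c2ccc(NS(C)(=O)=O)c(F)c2)CC1` gives 0.1 nM in an assay on CHO cells for antagonist activity at transient receptor potential cation channel subfamily V member 1 (Homo sapiens), read by FLIPR and calcium flux (on this read-out lower numbers stand for stronger inhibition and higher numbers for weaker inhibition), the lowest of the three numbers recorded. Compound 1 `CC(C(=O)NCc1ccc(C(F)(F)F)nc1CCC(C)(C)C)c1ccc(NS(C)(=O)=O)c(F)c1` gives 0.6 nM in this assay, and compound 2 `CC(C(=O)NCc1ccc(C(F)(F)F)nc1C1=CCCCC1)c1ccc(NS(C)(=O)=O)c(F)c1` gives 0.7 nM; both sit well above compound 3, with a 6.0-fold lower number from compound 1 to compound 3 (0.78 log units; beyond the scatter) and a 7.0-fold lower number from compound 2 to compound 3 (0.85 log units; beyond the scatter), while a 1.2-fold higher number from compound 1 to compound 2 (0.07 log units; within the scatter). Compound 4 `CCC/C=C/c1nc(C(F)(F)F)ccc1CNC(=O)C(C)c1ccc(NS(C)(=O)=O)c(F)c1` is not yet measured. It differs from compound 3 in one place: pent-1-en-1-yl in place of 4-ethylcyclohex-1-en-1-yl on an aromatic carbon. Going by the values given here, two measured steps bear on this. The move from compound 2 to compound 3 showed what the ethyl on the saturated ring carbon is worth, and the move from compound 1 to compound 3 showed the gain of the 4-ethylcyclohex-1-en-1-yl over an acyclic group. Compound 4 keeps neither the ring nor the ethyl, so the expected outcome is a modest move back toward the numbers of compound 1 and compound 2, that is an 8.0-fold higher number from compound 3 to compound 4 (0.90 log units; beyond the scatter). On this basis compound 4 is estimated at 0.8 nM in this assay, with a range from 0.3 nM to 3 nM.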

Compound 4, inhibition constant: 0.9 nM
Compound 4: the middle estimate sits 1.1-fold (0.05 log units) below what was measured, within the range that was stated.
By their numbers in this assay, from the lowest: compound 3; then compounds 1, 2 and 4 (each within the scatter of the next).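

Replacing the 4-ethylcyclohex-1-en-1-yl of compound 3 with pent-1-en-1-yl in this assay gave a clear loss (a 9.0-fold higher number from compound 3 to compound 4 (0.95 log units; beyond the scatter)), so a double bond at this aromatic carbon next to the ring nitrogen did not by itself preserve the number of compound 3. The pent-1-en-1-yl group instead stayed level with both the cyclohex-1-en-1-yl group (a 1.3-fold higher number from compound 2 to compound 4 (0.11 log units; within the scatter)) and the 3,3-dimethylbutyl group (a 1.5-fold higher number from compound 1 to compound 4 (0.18 log units; within the scatter)). A ring alone therefore did not set a compound apart here, as compound 2 shows, and among these four only compound 3 stands clear of the others.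

Nothing available here explains the separate standing of compound 3. Also open, on these data alone, is whether a longer chain such as hept-1-en-1-yl, or an amine on the cyclohexene ring in place of the ethyl, would reach the number of compound 3.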